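From fluoro to hydroxy at the assay limit

A few compounds are considered here, and "the series" means these few. Any claim that something is new, unique, unknown or untested is made for them only; others in the source may bear on it.

In a functional assay on KYSE-410 cells (Homo sapiens) for antiproliferative activity, read by MTT assay, with a stated time of 72 h (a lower number here means a stronger inhibitor, a higher number a weaker inhibitor), compound 1 `O=C(Nc1cccc(OC(F)(F)F)c1)c1cc(=O)[nH]c2cc(Br)ccc12` gives 14000 nM. Compound 2 `O=C(Nc1cccc(F)c1)c1cc(=O)[nH]c2cc(F)ccc12` reads > 20000 nM, which is a limit and not a number. Compound 3 `O=C(Nc1cc(F)cc(F)c1)c1cc(=O)[nH]c2cc(F)ccc12` reads > 20000 nM, which is likewise a limit. Going by these compounds, compound 3 therefore stands at the limit of > 20000 nM in this assay, at which 2 of the 3 values shown sit, and its true position is unknown.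

Compound 4 `O=C(Nc1cc(F)cc(F)c1)c1cc(=O)[nH]c2cc(O)ccc12` differs from compound 3 by hydroxy in place of fluoro on an aromatic carbon, with hydroxy in place of fluoro on an aromatic carbon. Within the data shown here, the only measured single-place step, a step that the two limits leave unreadable from compound 2 to compound 3, is a different exchange and provides no readable size. Among the measured compounds shown here, the one numerical reading, 14000 nM for compound 1, comes from a compound that differs from compound 3 in more than one place. It shows only where a reading can fall in this series.

No size or direction can therefore be carried over. In this assay the step expected is a number no higher from compound 3 to compound 4 (the limit leaves the size open), with neither direction firmly favoured. For compound 4 the estimated value is 20000 nM, with an expected range of 6000 nM to 50000 nM.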

Compound 4, half-maximal inhibitory concentration: > 20000 nM
Compound 4: no number, only a limit (the forecaster's own chance of this, stated with the estimate: 60%); the middle value lies on the limit itself.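

Among these compounds, compound 3 and compound 4 both read as limits, not numbers, in this assay, and no step between them can be read. The compounds shown leave open whether fluoro or hydroxy at this place gives the stronger inhibitor, and where either compound truly stands: the limit of > 20000 nM in this assay, at which 3 of the 4 values shown sit.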